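This account rests on a few compounds, and the source may have more. Where it says the series, first, only, none or still open, it means among the compounds named here.

Series notes. Compound 1 `COc1ccc(/C=C/C(=O)c2ccc(NC(=O)CBr)cc2)cc1` gives 34% in a functional assay on the whole organism (strain albino) for inhibition, with Rattus norvegicus as the target, read by paw edema, with stated times of 30 min and 5 h, at a dose of 100 mg/kg by the oral route; a lower number here means less inhibition, a higher number more inhibition at the dose given (going by the name of the read-out). Within the data shown here, compound 2 `COc1ccc(/C=C/C(=O)c2ccc(NC(=O)CO[N+](=O)[O-])cc2)cc1` gives 46% in this assay; the step of a number 12 percentage points higher from compound 1 to compound 2 (beyond the scatter) is the only measured step in the set. Compound 3 `CC(Br)C(=O)Nc1ccc(C(=O)/C=C/c2ccc(Cl)cc2)cc1` gives 50% in this assay, the largest of the three numbers as they stand: its gap to compound 2 lies within the scatter, its gap to compound 1 beyond it. Compound 4 `COc1ccc(/C=C/C(=O)c2ccc(NC(=O)C(C)Br)cc2)cc1` differs from compound 3 by methoxy in place of chloro on an aromatic carbon. Among the measured compounds shown here, no measured step touches an aromatic carbon; the one known step, nitrooxy in place of bromo on the chain, does not bear on this change. With nothing pointing either way, the expected step of a number 4 percentage points lower from compound 3 to compound 4 (within the scatter) in this assay is none beyond the scatter. Compound 4 is therefore estimated at 46%, range 30% to 62%.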

Compound 4, a percentage reported as inhibition, in the whole organism at one dose (the size of the read-out at that dose, not a potency): 31%
For compound 4 the middle estimate is 15 percentage points above the measured one; the measured number falls inside the stated range.
By their numbers in this assay, from the lowest: compounds 4 and 1 (each within the scatter of the next); then compounds 2 and 3 (each within the scatter of the next).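

The step of a number 19 percentage points lower from compound 3 to compound 4 (beyond the scatter) shows that methoxy in place of chloro on the aromatic carbon counts in this assay and that this position is not silent. With methoxy kept, the step of a number 3 percentage points lower from compound 1 to compound 4 (within the scatter) shows no readable effect of the added methyl on the chain, while the step of a number 15 percentage points lower from compound 2 to compound 4 (beyond the scatter) places 1-bromoethyl under (nitrooxy)methyl. Nothing at hand gives a reason for these steps. Open: how fluoro, methyl or a dimethylamino group would read at the aromatic position, and whether nitrooxy on the chain keeps its gain alongside chloro.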